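A few compounds are considered here, and "the series" means these few. Any claim that something is new, unique, unknown or untested is made for them only; others in the source may bear on it.

Compound 1 `O=C(NCc1cc(Cl)ccc1-n1cnnn1)[C@@H]1C[C@@H]2C[C@@H]2N1C(=O)[C@H](O)Cc1ccccn1`: 1.2 10^-6 cm/s
Compound 2 `CC(C)(C)[C@@H](O)C(=O)N1C[C@@H]2C[C@@H]2[C@H]1C(=O)NCc1cc(Cl)ccc1-n1cnnn1`: 17 10^-6 cm/s

In an ADME assay on Caco-2 cells (Homo sapiens) for permeability, read by LC-MS, in the apical to basolateral direction, with a stated time of 60 min, at pH 6.5 (on this read-out higher numbers stand for higher permeability and lower numbers for lower permeability), compound 1 gives 1.2 10^-6 cm/s, the lowest of the two numbers recorded. Compound 2 gives 17 10^-6 cm/s in this assay, a gap that lies beyond the usual scatter of repeated measurements. Compound 3 `O=C(NCc1cc(Cl)ccc1-n1cnnn1)[C@@H]1C[C@@H]2C[C@@H]2N1C(=O)[C@H](O)CC1CC1` has not yet been measured. It differs from compound 1 in a single place: cyclopropyl in place of pyridin-2-yl on a saturated chain carbon, two bonds along the chain from a carbonyl carbon and an oxygen on a saturated carbon. Among the compounds with values here, no measured pair of compounds shows this exact change, so its size cannot be read directly from the data. Compound 3 is nonetheless expected to move upward in this assay, by a step of about a 7.5-fold higher number from compound 1 to compound 3 (0.88 log units; beyond the scatter) from compound 1, an expectation that leans on compound 2 because compound 2 gives 17 10^-6 cm/s with a saturated group in the corresponding place. Compound 3 is therefore estimated at 9 10^-6 cm/s, with a likely range from 3.5 10^-6 cm/s to 22 10^-6 cm/s.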

Compound 3, apparent permeability: 3.6 10^-6 cm/s
Estimate against measurement, compound 3: 2.5-fold (0.40 log units) above; low and high end bracket the measured number.
By their numbers in this assay, from the lowest: compound 1; then compound 3; then compound 2.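

In this assay, within the data shown here, the change of pyridin-2-yl to cyclopropyl gives the first direct reading at this position (a 3.0-fold higher number from compound 1 to compound 3 (0.48 log units; beyond the scatter)), a modest step with the rest of compound 1 held fixed. It shows that the read-out responds to the group carried on this saturated chain carbon, and that in this one pair the smaller carbon-only ring, without a hydrogen-bond acceptor, stands on the higher side. Nothing measured here accounts for the step.

The compounds shown leave open whether the step follows the loss of the ring nitrogen, the change in ring size or the loss of aromaticity, since all three change together. Phenyl or cyclohexyl in the same place would begin to separate these differences.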